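Swapping the pyridin-2-yl group of compound 3

This account rests on a few compounds, and the source may have more. Where it says the series, first, only, none or still open, it means among the compounds named here.

Values in a functional assay on EC9706 cells (Homo sapiens) for antiproliferative activity, read by MTT assay, with a stated time of 72 h; a higher number here means a weaker inhibitor, a lower number a stronger inhibitor:
- compound 1 `C/C(=N\NC(=O)c1cccc(S(=O)(=O)N2CCOCC2)c1)c1cccc(N)c1`: > 100000 nM (a limit of the assay, not a number)
- compound 2 `C/C(=N\NC(=O)c1cccc(S(=O)(=O)N2CCOCC2)c1)c1cc(O)ccc1O`: 3510 nM
- compound 3 `O=C(N/N=C/c1ccccn1)c1cccc(S(=O)(=O)N2CCOCC2)c1`: 44300 nM

Compound 3 has the higher of the two true numbers, and compound 2 sits lower at 3510 nM. Compound 4 `O=C(N/N=C/c1cc(Br)cc(Br)c1O)c1cccc(S(=O)(=O)N2CCOCC2)c1` differs from compound 3 by one change: 3,5-dibromo-2-hydroxyphenyl in place of pyridin-2-yl on a carbon with a double bond to nitrogen. For the measured compounds named here, one measured step bears on it, a large one on the same kind of carbon: an at least 28-fold lower number from compound 1 to compound 2 (1.45 log units; beyond the scatter). There, 2,5-dihydroxyphenyl entered, a group that also carries hydroxy. This is a single case, so the expectation is loose. A lower number is expected in this assay, an estimated 15-fold lower number from compound 3 to compound 4 (1.17 log units; beyond the scatter). Compound 4 is expected near 3000 nM, with an estimated range of 500 nM to 18000 nM.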

Compound 4, half-maximal inhibitory concentration: 2440 nM
Compound 4: middle estimate off by 1.2-fold (0.09 log units), on the high side; the range from low to high includes it.
By their numbers in this assay, from the lowest: compounds 4 and 2 (each within the scatter of the next); then compound 3. At a limit, above all of these: compound 1.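

In this assay there is an 18-fold lower number from compound 3 to compound 4 (1.26 log units; beyond the scatter), so a large step now appears on a second carbon with a double bond to nitrogen, one without the methyl that compound 1 and compound 2 carry there. Both ends of this step are true values, so its size is a number rather than a limit. Nothing given here explains the step. The hydroxy and the two bromines entered together, so their shares cannot be told apart. A 2-hydroxyphenyl group and a 3,5-dibromophenyl group on this carbon would separate them.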